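Sulfonyl aryl swaps on a bipiperidine sulfonamide core

The source may report more compounds than this note shows. Statements on the series, on what has been measured and on what is new or still open speak of the compounds shown alone.

Compound 1 `CC1CCN(C2CCN(S(=O)(=O)c3ccccc3Br)CC2)CC1`: 3 nM
Compound 2 `Cc1cccc(S(=O)(=O)N2CCC(N3CCC(C)CC3)CC2)c1`: 25 nM
Compound 3 `CC1CCN(C2CCN(S(=O)(=O)c3nccn3C)CC2)CC1`: > 5000 nM

In a functional assay on DLD-1 cells (Homo sapiens) for antiproliferative activity, read by CellTiter-Glo, with a stated time of 72 h (a lower number here means a stronger inhibitor, a higher number a weaker inhibitor), compound 1 gives 3 nM, and compound 2 gives 25 nM, a step of an 8.3-fold higher number from compound 1 to compound 2 (0.92 log units; beyond the scatter). Compound 3 stands apart: its value in this assay is only a limit, > 5000 nM, which is the limit of > 5000 nM in this assay, at which 1 of the 3 values shown sits. The steps of an at least 1600-fold higher number from compound 1 to compound 3 (3.22 log units; beyond the scatter) and an at least 200-fold higher number from compound 2 to compound 3 (2.30 log units; beyond the scatter) show that replacing either of the benzene-based groups on the sulfonyl sulfur with 1-methyl-1H-imidazol-2-yl removes measurable activity.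

Compound 4 `Cc1nc(Cl)sc1S(=O)(=O)N1CCC(N2CCC(C)CC2)CC1` differs from compound 3 by 2-chloro-4-methyl-1,3-thiazol-5-yl in place of 1-methyl-1H-imidazol-2-yl on a sulfonyl sulfur. Among the compounds with values here, no measured step covers this exchange of one five-membered heteroaryl for another; the only measured steps bearing on it are the large losses from compound 1 and compound 2 to compound 3. Whether the thiazolyl behaves more like the phenyl groups of compound 1 and compound 2 or like the imidazolyl of compound 3 is not settled by these data, so the step is expected to be uncertain but more likely downward in this assay, an at least 16-fold lower number from compound 3 to compound 4 (1.22 log units; beyond the scatter). Compound 4 is estimated at 300 nM, between 20 nM and 5000 nM.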

Compound 4, half-maximal inhibitory concentration: 1.6 nM
Compound 4: the middle estimate sits 190-fold (2.27 log units) above what was measured; the measured number lies below the stated range.
By their numbers in this assay, from the lowest: compounds 4 and 1 (each within the scatter of the next); then compound 2. At a limit, above all of these: compound 3.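

On the sulfonyl sulfur, a five-membered aromatic ring with 2 hetero atoms does not in itself remove activity in this assay, since 2-chloro-4-methyl-1,3-thiazol-5-yl in place of 1-methyl-1H-imidazol-2-yl gives an at least 3100-fold lower number from compound 3 to compound 4 (3.49 log units; beyond the scatter). The value of compound 3 in that step is a limit and not a number: the limit of > 5000 nM in this assay, at which 1 of the 4 values shown sits. The thiazolyl group also gives a 16-fold lower number from compound 2 to compound 4 (1.19 log units; beyond the scatter), while a 1.9-fold lower number from compound 1 to compound 4 (0.27 log units; within the scatter) lies within the scatter, so no order can be given between it and the 2-bromophenyl group.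

The compounds shown leave open whether the activity rests on the thiazole ring itself or on its chlorine and methyl groups. A plain 1,3-thiazol-5-yl group, or one carrying an amine in place of the chlorine, would bear on that question.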